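Chloro added to the pendant phenyl of compound 2

The source may report more compounds than this note shows. Statements on the series, on what has been measured and on what is new or still open speak of the compounds shown alone.

Measured compounds and their values in a functional assay on MIA PaCa-2 cells (Homo sapiens) for antiproliferative activity, read by sulforhodamine B assay, with a stated time of 48 h; on this read-out lower numbers stand for stronger inhibition of growth and higher numbers for weaker inhibition of growth:
compound 1, `O=C(NCc1cn(Cc2ccc(C(F)(F)F)cc2)nn1)c1cn(-c2ccccc2)nc1-c1ccccc1`, 17700 nM
compound 2, `COc1ccc(Cn2cc(CNC(=O)c3cn(-c4ccccc4)nc3-c3ccccc3)nn2)cc1`, 10200 nM
compound 3, `COc1cc(Cn2cc(CNC(=O)c3cn(-c4ccccc4)nc3-c3ccccc3)nn2)cc(OC)c1OC`, 1000 nM

Compound 2 stands second highest of the three numbers in this assay. Its nearest neighbour is compound 1, with the step of a 1.7-fold lower number from compound 1 to compound 2 (0.24 log units; within the scatter), which lies within the scatter. Its furthest neighbour is compound 3, reached by a 10-fold lower number from compound 2 to compound 3 (1.01 log units; beyond the scatter), a large step beyond the scatter; the related step of an 18-fold lower number from compound 1 to compound 3 (1.25 log units; beyond the scatter) is of the same kind. All three measured steps alter the substituted benzyl group on the triazole nitrogen and leave the rest of the shared core untouched.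

Compound 4, `COc1ccc(Cn2cc(CNC(=O)c3cn(-c4ccccc4)nc3-c3ccc(Cl)cc3)nn2)cc1`, differs from compound 2 elsewhere: chloro in place of hydrogen on an aromatic carbon, the change placed on an aromatic carbon of a six-membered aromatic ring of carbon only, para to a large group. Within the data shown here, no measured step touches this part of the core, so nothing among the measured compounds bears on the change directly. In the absence of any relevant step, the expectation is no movement beyond the scatter, with compound 4 expected to sit close to compound 2, i.e. an expected step of a 1.0-fold lower number from compound 2 to compound 4 (0.01 log units; within the scatter). Compound 4 is therefore estimated at 10000 nM in this assay, within a range from 4000 nM to 25000 nM.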

Compound 4, concentration for 50% growth inhibition: 290 nM
Compound 4: middle estimate off by 34-fold (1.54 log units), on the high side, outside the stated range (below it).
By their numbers in this assay, from the lowest: compound 4; then compound 3; then compounds 2 and 1 (each within the scatter of the next).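

The core is not a silent part of the series: the phenyl to 4-chlorophenyl change, with chloro para to a large group on a six-membered aromatic ring of carbon only, gives a 35-fold lower number from compound 2 to compound 4 (1.55 log units; beyond the scatter) in this assay. Among these compounds, until now, large steps had been seen only on the substituted benzyl group on the triazole nitrogen, whereas this one arises with that group held as in compound 2, and a single added chlorine atom is enough to produce it. No measurement shown here accounts for the size of this step, so it stands as an observation without an explanation.

Open, as far as these compounds go, is whether the step belongs to chloro itself or would also appear with fluoro, bromo, methyl, methoxy or a dimethylamino group at the same carbon, and whether moving the chloro elsewhere on this phenyl would retain it. Also open, from the compounds shown here alone, is whether 4-chlorophenyl and the 3,4,5-trimethoxyphenyl group of compound 3, which gives a 10-fold lower number from compound 2 to compound 3 (1.01 log units; beyond the scatter) on its own, would add up when combined in a single compound.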